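Two methyls become two methoxys on a carbonyl-bound ring

The source may hold more compounds than are shown below. What is called first, only, known or untested is meant among the compounds shown, and "the series" means these compounds.

Three measured compounds share one core and differ only in the ring attached to the carbonyl carbon. In a functional assay on DU-145 cells (Homo sapiens) for antiproliferative activity, read by MTT assay, with a stated time of 24 h (a higher number here means a weaker inhibitor, a lower number a stronger inhibitor), compound 1 `COc1ccc(C(=O)/C=C/c2cc(-c3cc(OC)c(OC)c(OC)c3)n3nc(-c4ccccc4)cc3n2)cc1` gives 25200 nM, compound 2 `COc1cc(C(=O)/C=C/c2cc(-c3cc(OC)c(OC)c(OC)c3)n3nc(-c4ccccc4)cc3n2)cc(OC)c1OC` gives 34900 nM, and compound 3 `COc1cc(-c2cc(/C=C/C(=O)c3ccc(C)c(C)c3)nc3cc(-c4ccccc4)nn23)cc(OC)c1OC` gives 15400 nM, the lowest of the three numbers, although only a 2.3-fold lower number from compound 2 to compound 3 (0.36 log units; beyond the scatter) lies beyond the scatter while a 1.6-fold lower number from compound 1 to compound 3 (0.21 log units; within the scatter) does not. Compound 4 `COc1ccc(C(=O)/C=C/c2cc(-c3cc(OC)c(OC)c(OC)c3)n3nc(-c4ccccc4)cc3n2)cc1OC` differs from compound 3 by 3,4-dimethoxyphenyl in place of 3,4-dimethylphenyl on a carbonyl carbon. Both steps toward compound 3 swapped methoxy-bearing rings for the methyl-bearing ring, and this change runs the other way, so a modest rise in this assay is expected. Compound 4 is therefore estimated at 27000 nM, between 12000 nM and 60000 nM, which means an expected 1.8-fold higher number from compound 3 to compound 4 (0.24 log units; within the scatter).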

Compound 4, half-maximal inhibitory concentration: 29900 nM
Beside the measured number, compound 4's estimate is 1.1-fold (0.04 log units) below it; the measured number falls inside the stated range.
By their numbers in this assay, from the lowest: compounds 3, 1, 4 and 2 (each within the scatter of the next, the first and the last beyond it).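

In this assay the change to 3,4-dimethoxyphenyl in place of 3,4-dimethylphenyl on the carbonyl carbon gives a 1.9-fold higher number from compound 3 to compound 4 (0.29 log units; within the scatter) and so cannot be told apart from no change. One methoxy more on the ring gives a 1.2-fold higher number from compound 1 to compound 4 (0.07 log units; within the scatter) and one methoxy fewer gives a 1.2-fold lower number from compound 2 to compound 4 (0.07 log units; within the scatter) so single methoxy steps on this ring also stay unresolved. No supporting data explain these numbers. Open, going by these compounds, is whether an amine or a carboxylic acid on this ring would give a step beyond the scatter.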